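Swapping Methoxy for Methyl on a Hydroxamate Sulfonamide

A few compounds are considered here, and "the series" means these few. Any claim that something is new, unique, unknown or untested is made for them only; others in the source may bear on it.

Compound 1 `Cc1ccc(S(=O)(=O)N(CCN=[N+]=[N-])[C@@H](C(=O)NO)C(C)C)cc1` gives 4 nM in an assay on isolated protein for inhibition of matrix metalloproteinase-9 (Homo sapiens), read by fluorescence, with a stated time of 30 min; on this read-out higher numbers stand for weaker inhibition and lower numbers for stronger inhibition.
Compound 2 `COc1ccc(S(=O)(=O)N(CCn2cc(CCCF)nn2)[C@@H](C(=O)NO)C(C)C)cc1` gives 0.07 nM in this assay.
Compound 3 `COc1ccc(S(=O)(=O)N(CCn2cc(CNS(=O)(=O)c3ccc(F)cc3)nn2)[C@@H](C(=O)NO)C(C)C)cc1` gives 0.6 nM in this assay.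

Compound 2 has the lowest number of the three, and each of the other two stands beyond the scatter above it. Within the data shown here, the one single-point step measured so far, an 8.6-fold higher number from compound 2 to compound 3 (0.93 log units; beyond the scatter), concerns a group on the triazole side of the molecule and says nothing about the ring that carries the methoxy. Compound 4 `Cc1ccc(S(=O)(=O)N(CCn2cc(CCCF)nn2)[C@@H](C(=O)NO)C(C)C)cc1` differs from compound 2 by methyl in place of methoxy on an aromatic carbon. Compound 1 also carries a methyl on that ring, but it differs from compound 2 in a second place too, so its number cannot be read as the effect of this one change. Among the measured compounds shown here, with no guiding step, the move from compound 2 to compound 4 in this assay is expected to be small, estimated at a 2.1-fold higher number from compound 2 to compound 4 (0.33 log units; beyond the scatter). Compound 4 is expected to give 0.15 nM, within a range from 0.04 nM to 0.6 nM.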

Compound 4, half-maximal inhibitory concentration: 3 nM
Compound 4: the middle estimate sits 20-fold (1.30 log units) below what was measured; the measured number lies above the stated range.
By their numbers in this assay, from the lowest: compound 2; then compound 3; then compounds 4 and 1 (each within the scatter of the next).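

In this assay, methyl in place of methoxy at this place, para to a large group, is no minor swap: it gives a 43-fold higher number from compound 2 to compound 4 (1.63 log units; beyond the scatter). With methyl on the ring, changing the group at the other end of the molecule gives a 1.3-fold lower number from compound 1 to compound 4 (0.12 log units; within the scatter), which lies within the scatter, so the ring substituent here counts for more than that chain change. No measurement shown explains this difference. From the compounds shown here alone, how a hydroxyl, an ethoxy group or a chlorine would compare at this place remains open, as does whether the chain change would matter as little with methoxy on the ring.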